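The source may hold more compounds than are shown below. What is called first, only, known or untested is meant among the compounds shown, and "the series" means these compounds.

Measured so far:
Compound 1, `CCOC(=O)c1cccc(-c2ccc(CN3CCCCC3)cc2)c1`: 68%
Compound 2, `CCOc1ccc(-c2cccc(S(=O)(=O)N(C)C)c2)cc1`: 63%

Both compounds were tested in an assay on COS-7 cells for inhibition of patatin-like phospholipase domain-containing protein 2 (Mus musculus), tested at 200 uM; a lower number here means less inhibition, a higher number more inhibition at the concentration tested (going by the name of the read-out). Compound 1 gives 68% in this assay, and compound 2 gives 63%. Among the compounds with values here, of the two numbers, the one for compound 2 is written the smaller, but the distance to compound 1 lies within the scatter of repeated measurements, so the two compounds cannot be separated on this read-out.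

The next compound, compound 3, `CCOc1ccc(-c2cccc([N+](=O)[O-])c2)cc1`, shares its core with compound 2 and differs from it in one place: nitro in place of dimethylsulfamoyl on an aromatic carbon

Within the data shown here, no pair of measured compounds shows a swap of this kind, so there is no measured step to lean on. What the two measured numbers do show is that two quite different substitution patterns on the same kind of core land within the scatter of each other. On that basis the step from compound 2 to compound 3 is expected to be small, a number 8 percentage points lower from compound 2 to compound 3 (within the scatter), pointing slightly downward but not clearly beyond the scatter. Compound 3 is therefore estimated at 55%, with a range from 30% to 78%.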

Compound 3, a percentage reported as inhibition, at one concentration (the size of the read-out at that concentration, not a potency): 35%
Compound 3: the middle estimate sits 20 percentage points above what was measured; low and high end bracket the measured number.
By their numbers in this assay, from the lowest: compound 3; then compounds 2 and 1 (each within the scatter of the next).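

Within the data shown here, compound 2 and compound 3 are the first pair here that differ in only one place, so this is the first direct look at what the group on this aromatic carbon, meta to a group of 9 heavy atoms, does in this assay: nitro in place of dimethylsulfamoyl gives a number 28 percentage points lower from compound 2 to compound 3 (beyond the scatter). The two groups match in their counts of hydrogen-bond donors and acceptors and neither carries a net charge, so those counts alone do not settle the read-out at this position, although the group that leaves has 6 heavy atoms and the one that enters has 3. Nothing at hand shows which difference between the two groups lies behind this step.

The compounds shown leave open how other groups on this same carbon would behave, for instance an amine, a carboxylic acid or a simple methyl group. They also leave open whether the same swap would give a step of similar size on a different core, such as that of compound 1.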